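Nitro for Cyano on a Second Anilide Core

A few compounds are considered here, and "the series" means these few. Any claim that something is new, unique, unknown or untested is made for them only; others in the source may bear on it.

Measured compounds:
compound 1, `CC(CSc1ccc(F)cc1)C(=O)Nc1ccc(C#N)c(C(F)(F)F)c1`, 8690 nM
compound 2, `CC(CSc1ccc(F)cc1)C(=O)Nc1ccc([N+](=O)[O-])c(C(F)(F)F)c1`, 27200 nM
compound 3, `CC(CSc1cc(C(F)(F)F)cc(C(F)(F)F)c1)C(=O)Nc1ccc(C#N)cc1C(F)(F)F`, 4570 nM

In a functional assay on LNCaP cells (Homo sapiens) for antiproliferative activity, read by MTT assay, with a stated time of 96 h (a lower number here means a stronger inhibitor, a higher number a weaker inhibitor), compound 1 gives 8690 nM and compound 2 gives 27200 nM. Between them stands one change, (nitro in place of cyano on an aromatic carbon), and it made the step of a 3.1-fold higher number from compound 1 to compound 2 (0.50 log units; beyond the scatter). Compound 3, which gives 4570 nM, shares no counted difference with compound 1; how the two cores differ is not broken down here. Compound 4, `CC(CSc1cc(C(F)(F)F)cc(C(F)(F)F)c1)C(=O)Nc1ccc([N+](=O)[O-])cc1C(F)(F)F`, has not yet been measured. It differs from compound 3 by nitro in place of cyano on an aromatic carbon, the same kind of change, though here the entering group stands meta to a trifluoromethyl group rather than ortho to it. A step of similar size is expected, a 2.8-fold higher number from compound 3 to compound 4 (0.45 log units; beyond the scatter), resting on the step from compound 1 to compound 2, a 3.1-fold higher number from compound 1 to compound 2 (0.50 log units; beyond the scatter). Compound 4 is therefore estimated at 13000 nM, between 5000 nM and 35000 nM.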

Compound 4, half-maximal inhibitory concentration: 43700 nM
The estimate for compound 4 lay 3.4-fold (0.53 log units) below the measured number, outside the stated range (above it).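

Putting nitro in place of cyano gave a higher number on both cores in this assay, so the direction of the change carried over, but its size did not, with a 9.6-fold higher number from compound 3 to compound 4 (0.98 log units; beyond the scatter). Set side by side, the two steps differ by more than the scatter allows: the same change on two cores in this assay, a 3.1-fold higher number (0.50 log units; beyond the scatter) from compound 1 to compound 2 and a 9.6-fold higher number (0.98 log units; beyond the scatter) from compound 3 to compound 4, 3.1-fold (0.49 log units) apart, beyond the scatter of two such steps. This shows that the size of the step depends on the core that carries it, but the two cores differ in more than one place, and these compounds do not show which difference matters.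

Still open, on these data alone, is how an amine or a carboxylic acid on that same aromatic carbon would compare with cyano and nitro on either core. Also open, as far as these compounds go, is what size of step a third core would give.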